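This account rests on a few compounds, and the source may have more. Where it says the series, first, only, none or still open, it means among the compounds named here.

Measured in an ADME assay on microsomes from liver (Homo sapiens) for metabolic stability, read by LC-MS, using NADPH, with a stated time of 10 min, tested at 0.5 uM; a higher number here means that more of the compound is left, a lower number that less of the compound is left:
- compound 1 `CC(=O)Nc1cc(-c2ccc(OC[C@@](C)(N)CC(C)C)c(F)c2)ccn1`: 91%
- compound 2 `COC(=O)Nc1cc(-c2cnc(OC[C@@](C)(N)CC(C)C)c(Cl)c2)ccn1`: 90%
- compound 3 `CC(=O)Nc1cc(-c2ccc(OC[C@@H](N)CC(C)C)c(C)c2)ccn1`: 91%

In all three compounds, most of the material is still present at the end of the incubation with liver microsomes. Compound 2, at 90%, lies within the usual scatter of both compound 1 and compound 3, so this assay does not separate these three compounds. Small gaps like these should not be read as a ranking.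

The next compound to be tested is compound 4 `COC(=O)Nc1cc(-c2ccc(OC[C@@](C)(N)CC(C)C)nc2)ccn1`. It is reached from compound 2 by one change: hydrogen in place of chloro on an aromatic carbon. In words, hydrogen takes the place of chloro on an aromatic carbon.

Among the measured compounds shown here, no two measured compounds differ in only one place, so the data contain no direct measure of what a single swap does in this assay. For the measured compounds named here, the only guide is that the three measured compounds differ from one another in several places and still give values within the scatter. The expectation is therefore no step beyond the scatter, with a slight lean downward at most. The expected change is a number 2 percentage points lower from compound 2 to compound 4 (within the scatter). Compound 4 is estimated at 88%, with an expected range from 76% to 96%.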

Compound 4, percent of the compound remaining: 100%
Estimate against measurement, compound 4: 12 percentage points below, outside the stated range (above it).
By their numbers in this assay, from the lowest: compounds 2, 1, 3 and 4 (each within the scatter of the next).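

Among the compounds shown here, this pair gives the first direct reading of a single swap in this assay: hydrogen in place of chloro on an aromatic carbon of the six-membered aromatic ring with 1 nitrogen, ortho to the (2-amino-2,4-dimethylpentyl)oxy group, gives a number 10 percentage points higher from compound 2 to compound 4 (within the scatter). The step stays within the scatter, and compound 4 gives 100%, so the reading stays high without the chloro and this assay does not separate the two compounds. No measurement here explains the result, and none bears on what either chloro or hydrogen does at this carbon.

On these data alone, it remains open whether a larger group at this same carbon, such as methoxy, trifluoromethyl or a nitrile, would also leave the reading within the scatter of compound 2 and compound 4. The same swap on the ring without a nitrogen, or in the compounds carrying an acetyl group in place of the methyl carbamate, also stays unknown, since the single step shown comes from one pair.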